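Adding a Fluoro Where the Amide Side Ring Sits

The compounds below may be only part of what the source reports. "The series", "measured", "known", "first", "only" and "open" are said of these compounds alone.

In a functional assay on A549 cells (Homo sapiens) for cytotoxicity, read by MTT assay, with a stated time of 72 h (on this read-out lower numbers stand for stronger inhibition and higher numbers for weaker inhibition), compound 1 `O=C(Nc1ccc(Oc2ccnc3[nH]ccc23)c(F)c1)c1nn(-c2ccc(Br)cc2)ccc1=O` gives only a limit, > 60000 nM. Compound 2 `O=C(Nc1ccc(Oc2ccnc3[nH]ccc23)c(F)c1)c1nn(-c2ccc(Br)cc2F)ccc1=O` gives 55700 nM in this assay. The difference is fluoro in place of hydrogen on an aromatic carbon and the step is an at least 1.0-fold lower number from compound 1 to compound 2 (0.03 log units; that floor lies within the scatter), which is evidence of the limit of > 60000 nM in this assay, at which 2 of the 3 values shown sit. Compound 3 `Cc1cc(=O)n(-c2ccc(F)cc2)nc1C(=O)Nc1ccc(Oc2ncnc3[nH]ccc23)cc1` has a different core; how it differs from compound 1 is not broken down here. In this assay compound 3 gives only a limit, > 60000 nM. Compound 4 `Cc1cc(=O)n(-c2ccc(F)cc2)nc1C(=O)Nc1ccc(Oc2ncnc3[nH]ccc23)c(F)c1` differs from compound 3 by fluoro in place of hydrogen on an aromatic carbon, a place that is meta to a large group rather than meta to a bromo group, so it is the same kind of change. For compound 4 the estimated step is an at least 1.0-fold lower number from compound 3 to compound 4 (0.03 log units; that floor lies within the scatter), expected to be small because an at least 1.0-fold lower number from compound 1 to compound 2 (0.03 log units; that floor lies within the scatter) barely moved off (the limit of > 60000 nM in this assay, at which 2 of the 3 values shown sit). The expected value of compound 4 is 55000 nM, between 30000 nM and 90000 nM.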

Compound 4, half-maximal inhibitory concentration: 42400 nM
For compound 4 the middle estimate is 1.3-fold (0.11 log units) above the measured one; the range from low to high includes it.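

In this assay, fluoro in place of hydrogen on the core of compound 3 gives an at least 1.4-fold lower number from compound 3 to compound 4 (0.15 log units; that floor lies within the scatter). Set beside the same change on the core of compound 1, this shows no conflict between the two cores, but it does not show that the change carries over with a fixed size: the same change on two cores in this assay, an at least 1.0-fold lower number (0.03 log units; that floor lies within the scatter) from compound 1 to compound 2 and an at least 1.4-fold lower number (0.15 log units; that floor lies within the scatter) from compound 3 to compound 4; the limit leaves it open whether they differ Compound 1 and compound 3 each give only a limit, not a number, so neither step has an exact size: the limit of > 60000 nM in this assay, at which 2 of the 4 values shown sit.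

The compounds shown leave open whether an amine or a carboxylic acid on that same aromatic carbon would shift the number clearly. They also leave open how large the fluoro step would be on a core whose parent gives a true number.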